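A few compounds are considered here, and "the series" means these few. Any claim that something is new, unique, unknown or untested is made for them only; others in the source may bear on it.

Measured in a functional assay on Jurkat cells (Homo sapiens); a higher number here means a weaker inhibitor, a lower number a stronger inhibitor:

compound 1 `C[C@H](NC(=O)C(=O)NCC1CCCCC1)C(=O)N[C@@H](CC(=O)O)C(=O)COc1c(F)c(F)cc(F)c1F`: 19 nM
compound 2 `Cc1ccc(C)c(CNC(=O)C(=O)N[C@@H](C)C(=O)N[C@@H](CC(=O)O)C(=O)COc2c(F)c(F)cc(F)c2F)c1`: 11 nM
compound 3 `C[C@H](NC(=O)C(=O)NCc1ccc(Cl)cc1Cl)C(=O)N[C@@H](CC(=O)O)C(=O)COc1c(F)c(F)cc(F)c1F`: 165 nM

Compound 3 has the highest number of the three and is the weakest inhibitor measured here. The steps that lead to it are an 8.7-fold higher number from compound 1 to compound 3 (0.94 log units; beyond the scatter) and a 15-fold higher number from compound 2 to compound 3 (1.18 log units; beyond the scatter), both beyond the scatter.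

Still unmeasured is compound 4 `C[C@H](NC(=O)C(=O)NCc1cc(F)cc(F)c1)C(=O)N[C@@H](CC(=O)O)C(=O)COc1c(F)c(F)cc(F)c1F`, which keeps the rest of compound 3 and changes one group: 3,5-difluorophenyl in place of 2,4-dichlorophenyl on a saturated chain carbon bound to an amide-type nitrogen. That is, 3,5-difluorophenyl stands in place of 2,4-dichlorophenyl on a saturated chain carbon bound to an amide-type nitrogen.

Within the data shown here, no measured step makes this exchange, but all three change the same place. The step of a 1.7-fold lower number from compound 1 to compound 2 (0.24 log units; within the scatter) stays within the scatter, so in this small set a change of group here need not move the number. Only the 2,4-dichlorophenyl group of compound 3 stands apart. Three compounds are a thin basis, and none of them carries fluorine on this ring. A step to a lower number in this assay is therefore expected, probably smaller than a 15-fold higher number from compound 2 to compound 3 (1.18 log units; beyond the scatter).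

The expected change is a 3.7-fold lower number from compound 3 to compound 4 (0.56 log units; beyond the scatter).

For compound 4 the estimated value is 45 nM, with an expected range of 14 nM to 150 nM.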

Compound 4, half-maximal inhibitory concentration: 16 nM
Compound 4: the middle estimate sits 2.8-fold (0.45 log units) above what was measured; the measured number falls inside the stated range.
By their numbers in this assay, from the lowest: compounds 2, 4 and 1 (each within the scatter of the next); then compound 3.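

In this assay, the exchange of 2,4-dichlorophenyl for 3,5-difluorophenyl on a saturated chain carbon bound to an amide-type nitrogen gives a 10-fold lower number from compound 3 to compound 4 (1.01 log units; beyond the scatter), so a phenyl group carrying two halogen atoms does not by itself bring the high number seen for compound 3. The new compound also falls in with the two earlier ones, with a 1.5-fold higher number from compound 2 to compound 4 (0.16 log units; within the scatter) and a 1.2-fold lower number from compound 1 to compound 4 (0.07 log units; within the scatter), which leaves cyclohexyl, 2,5-dimethylphenyl and 3,5-difluorophenyl indistinguishable here and 2,4-dichlorophenyl alone standing apart among the four compounds. Nothing measured alongside these numbers accounts for the gap between the two halogen-bearing groups.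

Since the halogen and its place on the ring change together in this step, the compounds shown cannot separate the two, as neither 2,4-difluorophenyl nor 3,5-dichlorophenyl is among them. As far as these compounds go, it also remains open whether the number stays in the same range when this ring carries an amine or a carboxylic acid, or when a pyridine ring takes its place.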